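The source may report more compounds than this note shows. Statements on the series, on what has been measured and on what is new or still open speak of the compounds shown alone.

Compound 1 `COc1cc(/C=C2\CCC/C(=C\c3ccc(O)c(O)c3)C2=O)cc(OC)c1OC` was examined in a functional assay on HT-29 cells (Homo sapiens) for antiproliferative activity, read by MTT assay, with a stated time of 72 h (a higher number here means a weaker inhibitor, a lower number a stronger inhibitor), where compound 1 gives 8500 nM. Within the data shown here, of the two compounds measured so far, this is the highest number; the nearest is compound 2 `COc1cc(/C=C2\CCC/C(=C\c3ccccc3F)C2=O)cc(OC)c1OC`, which in this assay gives 1600 nM. Among the measured compounds shown here, the only step recorded, a 5.3-fold lower number from compound 1 to compound 2 (0.73 log units; beyond the scatter), exchanges the whole aryl group, 2-fluorophenyl in place of 3,4-dihydroxyphenyl on a double-bonded chain carbon bound to a double-bonded ring carbon, and so bears only loosely on the new compound. Compound 3 `COc1cc(/C=C2\CCC/C(=C\c3ccc(O)c(Cl)c3)C2=O)cc(OC)c1OC` differs from compound 1 by chloro in place of hydroxy on an aromatic carbon, a smaller change that also removes one hydroxy from the same ring. Because the step of a 5.3-fold lower number from compound 1 to compound 2 (0.73 log units; beyond the scatter) ran toward lower numbers when both hydroxy groups were lost, a modest move in the same direction is expected for compound 3, a 2.1-fold lower number from compound 1 to compound 3 (0.33 log units; beyond the scatter). Compound 3 is therefore estimated in this assay at 4000 nM, with a range from 1500 nM to 11000 nM.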

Compound 3, half-maximal inhibitory concentration: 3400 nM
Compound 3: the middle estimate sits 1.2-fold (0.07 log units) above what was measured; the measured number falls inside the stated range.
By their numbers in this assay, from the lowest: compound 2; then compound 3; then compound 1.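

In this assay, exchanging chloro for hydroxy on the aromatic carbon ortho to a hydroxy group gives a 2.5-fold lower number from compound 1 to compound 3 (0.40 log units; beyond the scatter) with the other hydroxy left in place, so this single position carries a change beyond the scatter on its own. The 3-chloro-4-hydroxyphenyl group still stands apart from the 2-fluorophenyl group, with a 2.1-fold higher number from compound 2 to compound 3 (0.33 log units; beyond the scatter) in the same assay, so this one exchange does not close the whole gap between compound 1 and compound 2. No measurement offered here explains either step.

On these data alone, it remains open whether bromo, methyl or an amine on this same carbon would give a number like that of compound 3. As far as these compounds go, it is also open what replacing the remaining hydroxy of compound 3 with chloro or hydrogen would do.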